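The compounds below may be only part of what the source reports. "The series", "measured", "known", "first", "only" and "open" are said of these compounds alone.

Measured compounds:
- compound 1, `CC#CC(CC(=O)O)c1ccc(OCc2ccc3nc(-c4ccc(CC)cc4)cn3c2)cc1`, 496 nM
- compound 2, `CC#CC(CC(=O)O)c1ccc(OCc2ccn3cc(-c4ccc(C(C)C)cc4)nc3c2)cc1`, 615 nM
- compound 3, `CC#CC(CC(=O)O)c1ccc(OCc2ccn3cc(-c4ccc(CC)cc4)nc3c2)cc1`, 671 nM

In an assay on isolated protein for agonist activity at Free fatty acid receptor 1 (Homo sapiens) (on this read-out lower numbers stand for an effect already at smaller amounts and higher numbers for an effect only at larger amounts of compound), compound 1 gives 496 nM, the smallest of the three numbers, yet its gaps to compound 2 at 615 nM and to compound 3 at 671 nM both sit within the scatter, so the three compounds cannot be told apart on these data.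

Compound 4, `CC#CC(CC(=O)O)c1ccc(OCc2ccc3nc(-c4ccc(C)cc4)cn3c2)cc1`, has not yet been measured. Its difference from compound 1 is hydrogen in place of methyl on a saturated chain carbon bound to an aromatic carbon; seen one bond further out, an ethyl becomes a methyl, a 4-ethylphenyl a 4-methylphenyl.

For the measured compounds named here, one measured step bears on this change. Between compound 2 and compound 3 a methyl is likewise replaced by hydrogen on a saturated chain carbon, though on a carbon that is also bound to a second saturated chain carbon, and that step reads a 1.1-fold higher number from compound 2 to compound 3 (0.04 log units; within the scatter). Shortening the alkyl on the phenyl thus left this assay unmoved in the one case that was measured. Compound 4 is therefore expected to sit close to compound 1, with a step of about a 1.1-fold higher number from compound 1 to compound 4 (0.05 log units; within the scatter), and no shift beyond the scatter in either direction is expected.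

Compound 4 is estimated at 560 nM, with a range from 250 nM to 1250 nM.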

Compound 4, half-maximal effective concentration: 507 nM
For compound 4 the middle estimate is 1.1-fold (0.04 log units) above the measured one; low and high end bracket the measured number.
By their numbers in this assay, from the lowest: compounds 1, 4, 2 and 3 (each within the scatter of the next).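

Taking the 4-ethylphenyl to a 4-methylphenyl gives, in this assay, a 1.0-fold higher number from compound 1 to compound 4 (0.01 log units; within the scatter), so this shortening on a saturated chain carbon bound to an aromatic carbon leaves the read-out within the scatter on this core as well. For the compounds shown here, until this result, shortening the alkyl on the phenyl had been read on one core only, and at a carbon also bound to a second saturated chain carbon; it can now be read on two cores, and the two readings agree: the same change on two cores in this assay, a 1.1-fold higher number (0.04 log units; within the scatter) from compound 2 to compound 3 and a 1.0-fold higher number (0.01 log units; within the scatter) from compound 1 to compound 4, 1.1-fold (0.03 log units) apart, within the scatter of two such steps. Among the compounds shown, then, the shortening of the alkyl on the phenyl gives no step beyond the scatter, and neither of the two steps goes against this.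

What stays open is whether this holds only for the alkyl groups shown, or also for a longer chain such as hexyl, or for an amine, in place of the methyl of the 4-methylphenyl. On these data alone, whether hydrogen in place of the whole alkyl, leaving a bare phenyl, would stay within the scatter on either core is equally open.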